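A few compounds are considered here, and "the series" means these few. Any claim that something is new, unique, unknown or untested is made for them only; others in the source may bear on it.

Series notes on a shared amide–sulfonamide core. Compound 1 `O=C(Nc1ccc(S(=O)(=O)NCc2ccccc2)cc1)c1ccc(Cl)cc1Cl` carries a benzyl group on the sulfonamide nitrogen. In a functional assay on HEK293 cells for agonist activity at probable G-protein coupled receptor 27 (Homo sapiens), read by a luciferase reporter and beta-arrestin recruitment, with a stated time of 10 min (a higher number here means that more compound is needed for the effect, a lower number that less compound is needed), compound 1 reaches only a limit of the assay, > 100000 nM, so no number is known for it; this is recorded as the limit of > 100000 nM in this assay, at which 1 of the 3 values shown sits. Compound 2 `O=C(Nc1ccc(S(=O)(=O)Nc2ccccc2)cc1)c1cc(F)c(Cl)cc1F` and compound 3 `O=C(Nc1ccc(S(=O)(=O)Nc2ccccc2)cc1)c1ccc(C(F)(F)F)cc1F` each carry a phenyl group on that nitrogen and both give measurable numbers. In this assay compound 2 gives 141 nM. In this assay compound 3 gives 363 nM.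

Compound 4 `O=C(Nc1ccc(S(=O)(=O)Nc2ccc(Cl)cc2)cc1)c1ccc(Cl)cc1Cl` differs from compound 1 in one place: 4-chlorophenyl in place of benzyl on a sulfonamide nitrogen. For the measured compounds named here, no pair of measured compounds isolates this change, so its size is not known directly. The expectation for compound 4 rests on compound 2 at 141 nM and on compound 3 at 363 nM, both with an aromatic ring directly on the sulfonamide nitrogen. Compound 1 with its benzyl stands apart from these two, with no measured number of its own. A large step toward less compound needed is expected, well beyond the scatter. Compound 4 is expected to come in near 300 nM, with a range from 50 nM to 5000 nM. The step expected is an at least 330-fold lower number from compound 1 to compound 4 (2.52 log units; beyond the scatter).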

Compound 4, half-maximal effective concentration: > 100000 nM
Compound 4: a limit, no number; the forecaster's own chance of this, stated with the estimate: 20%; at least 330-fold (2.52 log units) between middle value and limit.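

In this assay, for the compounds shown here, compound 1 and compound 4 each stand at a limit and not at a number, so no step between them can be read: the limit of > 100000 nM in this assay, at which 2 of the 4 values shown sit.

The compounds shown leave open which of the several differences separating compound 4 from compound 2 and compound 3 goes with the measurable values of those two.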